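Adding a methoxy to the 2-methoxyphenyl ring

A few compounds are considered here, and "the series" means these few. Any claim that something is new, unique, unknown or untested is made for them only; others in the source may bear on it.

Compound 1 `COc1cc(C(=O)c2sc3ccccc3c2-c2ccc(C)cc2)cc(OC)c1OC`: 1400 nM
Compound 2 `COc1ccccc1-c1c(C(=O)c2cc(OC)c(OC)c(OC)c2)sc2ccccc12`: 2900 nM

In a functional assay on HL-60 cells (Homo sapiens) for antiproliferative activity, read by MTT assay, with a stated time of 72 h (on this read-out lower numbers stand for stronger inhibition and higher numbers for weaker inhibition), compound 2 holds the higher of the two numbers, 2900 nM. Compound 3 `COc1ccc(-c2c(C(=O)c3cc(OC)c(OC)c(OC)c3)sc3ccccc23)c(OC)c1` follows from compound 2 by one change: methoxy in place of hydrogen on an aromatic carbon. The methoxy replaces hydrogen on an aromatic carbon, turning 2-methoxyphenyl into 2,4-dimethoxyphenyl.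

Going by the values given here, only one measured step bears on this: a 2.1-fold higher number from compound 1 to compound 2 (0.32 log units; beyond the scatter), a modest change that swaps 4-methylphenyl for 2-methoxyphenyl. Among the compounds with values here, no measured step adds a methoxy to a compound already carrying one, so the guide is indirect. A change no larger than that modest step is expected, probably within the scatter, with a slight lean towards a lower number. The expected step is a 1.3-fold lower number from compound 2 to compound 3 (0.12 log units; within the scatter). Compound 3 is estimated at 2200 nM, with an expected range of 700 nM to 7000 nM.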

Compound 3, half-maximal inhibitory concentration: 4600 nM
Beside the measured number, compound 3's estimate is 2.1-fold (0.32 log units) below it, within the range that was stated.
By their numbers in this assay, from the lowest: compound 1; then compounds 2 and 3 (each within the scatter of the next).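

In this assay, methoxy on the aromatic carbon para to a large group gives a 1.6-fold higher number from compound 2 to compound 3 (0.20 log units; within the scatter), so this added group does not separate 2,4-dimethoxyphenyl from 2-methoxyphenyl in this series. With 4-methylphenyl as the reference, the 2,4-dimethoxyphenyl ring gives a 3.3-fold higher number from compound 1 to compound 3 (0.52 log units; beyond the scatter), which leaves compound 1 apart from both methoxy-bearing compounds, each by a step beyond the scatter. No supporting data bear on the reason for these numbers.

The compounds shown leave open how a ring carrying only 4-methoxyphenyl would compare, since the methoxy at this carbon appears here only alongside the existing one. From the compounds shown here alone, it also remains open whether a hydroxyl or an amine on this same carbon would give a number apart from those of compound 2 and compound 3.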